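The compounds below may be only part of what the source reports. "The series", "measured", "known", "first", "only" and "open" are said of these compounds alone.

Compound 1 `O=C(CSC(=S)N[C@H]1CCOC1=O)Nc1ccc(Br)cc1` gives 67400 nM in a functional assay on EC9706 cells (Homo sapiens) for cytotoxicity, read by MTT assay, with a stated time of 72 h; on this read-out higher numbers stand for weaker inhibition and lower numbers for stronger inhibition. Compound 2 `O=C(CSC(=S)N[C@H]1CCOC1=O)Nc1ccc(F)cc1` gives 67100 nM in this assay. Compound 3 `O=C(CCl)Nc1ccc(C(=O)/C=C/c2ccc(Br)cc2)cc1` gives 10100 nM in this assay.

Compound 1 and compound 2 share one core and differ only by fluoro in place of bromo on an aromatic carbon. That exchange made a 1.0-fold lower number from compound 1 to compound 2 (0.00 log units; within the scatter), so the two are alike in effect. Compound 3 rests on another core; the difference between the two cores is not broken down here. Compound 4 `O=C(CCl)Nc1ccc(C(=O)/C=C/c2ccc(F)cc2)cc1` has not yet been measured and differs from compound 3 by fluoro in place of bromo on an aromatic carbon, the same change at the same place. A similar outcome is expected, so the step expected a 1.0-fold lower number from compound 3 to compound 4 (0.00 log units; within the scatter) is small because a 1.0-fold lower number from compound 1 to compound 2 (0.00 log units; within the scatter) was within the scatter. Compound 4 is therefore estimated at 10000 nM, expected to fall between 4000 nM and 25000 nM.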

Compound 4, half-maximal inhibitory concentration: 8600 nM
Compound 4: middle estimate off by 1.2-fold (0.07 log units), on the high side; low and high end bracket the measured number.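

Moved to a second core, the exchange of 4-bromophenyl for 4-fluorophenyl again left the number in this assay much where it stood (a 1.2-fold lower number from compound 3 to compound 4 (0.07 log units; within the scatter)). The two steps agree, so on these two cores the change carries over: the same change on two cores in this assay, a 1.0-fold lower number (0.00 log units; within the scatter) from compound 1 to compound 2 and a 1.2-fold lower number (0.07 log units; within the scatter) from compound 3 to compound 4, 1.2-fold (0.07 log units) apart, within the scatter of two such steps. Two cores are a small sample, however, and this does not show that a third core would respond in the same way, or that any other exchange at this place would carry over.

From the compounds shown here alone, both halogens gave alike results on each core, so it remains open what an amine, a carboxylic acid or a methoxy group at that place would do. A bare hydrogen there also remains untested among the compounds shown.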